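A few compounds are considered here, and "the series" means these few. Any claim that something is new, unique, unknown or untested is made for them only; others in the source may bear on it.

Measured compounds in the series:
compound 1, `CCCCCCCC/C=C/CCCCCCCCNCC(O)COc1cc(=O)oc2ccccc12` — > 100000 nM
compound 2, `O=c1cc(OCC(O)CN2CCCCC2)c2ccccc2o1` — "not determined" (no result reported)

Compound 1 gives only a limit in an ADME assay on Vero cells (Chlorocebus sabaeus) for cytotoxicity, read by fluorescence and resazurin assay, with a stated time of 72 h (a higher number here means that more compound is tolerated, a lower number that less compound is tolerated), namely > 100000 nM; this is a limit of the assay and not a measured concentration. Compound 2 carries no result in this assay. Compound 2 therefore stands nowhere on the numbers shown: the only value on record in the whole set is the limit (the limit of > 100000 nM in this assay, at which 1 of the 2 values shown sits), which belongs to compound 1, so compound 2 cannot be placed against anything.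

Compound 3, `CN1CCN(CC(O)COc2cc(=O)oc3ccccc23)CC1`, is the next member and has not yet been measured. The change from compound 2: 4-methylpiperazin-1-yl in place of piperidin-1-yl on a saturated chain carbon, two bonds along the chain from an oxygen on a saturated carbon. Within the data shown here, no measured step between the two exists. In this assay the step from compound 2 to compound 3 is expected to stay within the scatter, with no direction called, since nothing in hand argues for a shift either way; a reading at the limit of the assay is the likeliest outcome again. Compound 3 is estimated at 100000 nM, expected within 30000 nM to 300000 nM, most probably reported only as a limit.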

Compound 3, half-maximal cytotoxic concentration: > 100000 nM
Compound 3 gave a limit, no number; the forecaster's own chance of this, stated with the estimate: 70%; the middle value sits exactly at the limit.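

In this assay compound 3 gives > 100000 nM as a limit, not a number. Among these compounds, compound 2 carries no result, so no step from compound 2 to compound 3 can be read. The compounds shown leave open whether 4-methylpiperazin-1-yl in place of piperidin-1-yl changes tolerance at all, and where any of these compounds would give an actual number.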